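The compounds below may be only part of what the source reports. "The series", "measured", "known", "first", "only" and "open" are said of these compounds alone.

Working notes on the series. The shared core carries a variable ring on the carbon with a double bond to nitrogen. Compound 1 `Cc1c(C(=O)N/N=C\c2cccc(O)c2)oc2cccc(O)c12` gives 17600 nM in a functional assay on PC-3 cells (Homo sapiens) for inhibition; a higher number here means a weaker inhibitor, a lower number a stronger inhibitor. Compound 3 `COc1ccccc1/C=N\NC(=O)c1oc2cccc(O)c2c1C` gives 32700 nM in this assay, and the change from compound 1 to compound 3 is a 1.9-fold higher number from compound 1 to compound 3 (0.27 log units; within the scatter). Compound 2 `Cc1c(C(=O)N/N=C\c2ccncc2)oc2cccc(O)c12` reaches only the limit of this assay, reported as >= 40000 nM; the number itself is not known, so compound 2 stands at the top of the three values, as the limit of >= 40000 nM in this assay, at which 1 of the 3 values shown sits, records. Among the measured compounds shown here, the step of an at least 2.2-fold higher number from compound 1 to compound 2 (0.35 log units; beyond the scatter) is the only change here that is at least modest, whereas an at least 1.2-fold lower number from compound 2 to compound 3 (0.08 log units; that floor lies within the scatter) is small.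

Compound 4 `Cc1c(C(=O)N/N=C\c2ccco2)oc2cccc(O)c12` is not yet measured. It differs from compound 2 by furan-2-yl in place of pyridin-4-yl on a carbon with a double bond to nitrogen. For the measured compounds named here, no measured pair shows a furan-2-yl ring, so the step can only be read against the two steps that move away from pyridin-4-yl or towards it: an at least 2.2-fold higher number from compound 1 to compound 2 (0.35 log units; beyond the scatter) and an at least 1.2-fold lower number from compound 2 to compound 3 (0.08 log units; that floor lies within the scatter). Both point to a ring change on this carbon moving the number by a little, at most modestly. For compound 4 the expectation is therefore a step of an at least 1.3-fold lower number from compound 2 to compound 4 (0.12 log units; that floor lies within the scatter), with a real chance that only a limit is returned again. Compound 4 is estimated at 30000 nM, with a range from 12000 nM to 80000 nM.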

Compound 4, half-maximal inhibitory concentration: >= 40000 nM
Compound 4: a limit, no number (the forecaster's own chance of this, stated with the estimate: 45%); middle value at least 1.3-fold (0.12 log units) from the limit.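

Compound 4 is a limit in this assay, as compound 2 is, so a five-membered aromatic ring with oxygen and a six-membered aromatic ring with nitrogen now both give limits on the carbon with a double bond to nitrogen: the limit of >= 40000 nM in this assay, at which 2 of the 4 values shown sit.

Set against 3-hydroxyphenyl, furan-2-yl gives an at least 2.2-fold higher number from compound 1 to compound 4 (0.35 log units; beyond the scatter), a second change away from compound 1 that lies beyond the scatter. Compound 3 does not follow this pattern, since its step from compound 1 lies within the scatter, and an at least 1.2-fold higher number from compound 3 to compound 4 (0.08 log units; that floor lies within the scatter) does not separate it from compound 4 at that floor; the step between the two limits cannot be read.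

The compounds shown leave open how far compound 2 and compound 4 lie apart, and whether any group on this carbon gives a clearly lower number than compound 1 at 17600 nM. A phenyl ring carrying an amine or a carboxylic acid, or a longer chain in place of the ring, would show whether this position allows a larger change in either direction.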